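A few compounds are considered here, and "the series" means these few. Any claim that something is new, unique, unknown or untested is made for them only; others in the source may bear on it.

Compound 1 `CC(=O)CN1C(=O)NC(C)(c2ccc(S(N)(=O)=O)cc2)C1=O` reaches only a limit in a physicochemical assay for solubility, measured as kinetic solubility (a lower number here means a less soluble compound, a higher number a more soluble compound), recorded as >= 504000 nM. Within the data shown here, compound 2 `CC1(c2ccc(S(N)(=O)=O)cc2)NC(=O)N(CC(=O)C2CC2)C1=O` gives 58000 nM in this assay, the only plain number among the two values shown. Among the measured compounds shown here, the step of an at least 8.6-fold lower number from compound 1 to compound 2 (0.93 log units; beyond the scatter) is the sole measured change bearing on compound 3 `CC1(c2ccc(S(N)(=O)=O)cc2)NC(=O)N(CC(=O)C2CCCCC2)C1=O`, which differs from compound 2 by cyclohexyl in place of cyclopropyl on a carbonyl carbon. Since the earlier move to a larger group at this carbonyl lowered the reading, compound 3 is expected to sit lower again, a step of a 6.4-fold lower number from compound 2 to compound 3 (0.81 log units; beyond the scatter). Compound 3 is estimated at 9000 nM, within a range from 2500 nM to 30000 nM.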

Compound 3, solubility: >= 317000 nM
Compound 3: a limit, no number; the forecaster's own chance of this, stated with the estimate: 5%; middle value at least 35-fold (1.54 log units) away from the limit.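

Cyclohexyl in place of cyclopropyl on a carbonyl carbon gives, in this assay, an at least 5.4-fold higher number from compound 2 to compound 3 (0.73 log units; beyond the scatter), so the reading does not simply fall as the group on this carbon grows, and compound 2 is the one that breaks any such order. Going by these compounds, compound 3 is recorded only as a limit: the limit of >= 317000 nM in this assay, at which 1 of the 3 values shown sits. The step from compound 1 to compound 3 cannot be read, since both are limits: the limit of >= 504000 nM in this assay, at which 1 of the 3 values shown sits. Where the true reading of compound 3 lies stays open. So does whether a longer chain or an amine at this place would read like compound 2 or like compound 3.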